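This account rests on a few compounds, and the source may have more. Where it says the series, first, only, none or still open, it means among the compounds named here.

Three compounds have so far been measured in a physicochemical assay for lipophilicity, at pH 7.4; on this read-out lower numbers stand for lower lipophilicity and higher numbers for higher lipophilicity:

Compound 1, `CNC(=O)c1cc(C(=O)NCCO)cn(Cc2ccccc2)c1=O`: 1.9
Compound 2, `CNC(=O)c1cc(C(=O)NC2CC2)cn(Cc2cccc3[nH]c(C)nc23)c1=O`: 1.5
Compound 3, `CNC(=O)c1cc(C(=O)NC2CC2)cn(Cc2cccc3cc[nH]c23)c1=O`: 3.7

Compound 1 stands second highest of the three in this assay. Its nearest neighbour is compound 2, whose number is lower by a margin beyond the usual scatter of repeated measurements; compound 3 lies far above it, again beyond the scatter. No two of these compounds differ in only one place, so none of these gaps can be tied to a single structural change.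

Compound 4, `CNC(=O)c1cc(C(=O)NCCOC)cn(Cc2ccccc2)c1=O`, has not yet been measured in this assay. It differs from compound 1 in one place: methyl in place of hydrogen on an oxygen on a saturated carbon. Nothing measured here shows what this change does on its own, so the expectation rests on the starting point, compound 1, which gives 1.9. A small step upward is expected, a number 0.40 log units higher from compound 1 to compound 4 (beyond the scatter), toward higher lipophilicity, though a step of this size could still fall within the scatter. Compound 4 is therefore estimated at 2.3, with a range from 1.9 to 2.7.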

Compound 4, distribution coefficient: 2.7
Compound 4: middle estimate off by 0.40 log units, on the low side; the measured number falls inside the stated range.
By their numbers in this assay, from the lowest: compound 2; then compound 1; then compound 4; then compound 3.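

Among the compounds shown here, for the first time in this set, a gap can be tied to a single structural change: replacing 2-hydroxyethyl with 2-methoxyethyl gives, in this assay, a number 0.80 log units higher from compound 1 to compound 4 (beyond the scatter). The position is therefore not a silent one on this read-out, since a methyl that adds only one carbon, with no ring and no net charge, is enough to move the number by more than repeated measurements would scatter, and the rest of compound 1 stays the same. Nothing available explains why this swap moves the number by this amount.

This is a single pair, so it cannot show whether the step would be the same size on another chain or with other groups elsewhere on the shared core. Nor does it show how the number would respond if the end of the chain carried an ethoxy group, an amine or a carboxylic acid, or if the chain itself were longer.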